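This account rests on a few compounds, and the source may have more. Where it says the series, first, only, none or still open, it means among the compounds named here.

Measured in a functional assay on MCF7 cells (Homo sapiens) for inhibition, read by MTT assay, with a stated time of 72 h; a higher number here means a weaker inhibitor, a lower number a stronger inhibitor:
compound 1 `CNC(=O)CCCCCCCn1nc(-c2cnc3[nH]ccc3c2)c2c(N)ncnc21`: 7570 nM
compound 2 `Nc1ncnc2c1c(-c1cnc3[nH]ccc3c1)nn2CCCCCCCCC(=O)NO`: 24700 nM
compound 3 `Nc1ncnc2c1c(-c1cnc3[nH]ccc3c1)nn2CCCCCC(=O)NO`: > 150000 nM, a limit

The lowest actual number belongs to compound 1. The nearest gap is a 3.3-fold higher number from compound 1 to compound 2 (0.51 log units; beyond the scatter). For compound 3 there is only a limit, > 150000 nM.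

Compound 4 `CNC(=O)CCCCCCCn1nc(-c2ccc3oc(N)nc3c2)c2c(N)ncnc21` differs from compound 1 in one group: a group of 10 heavy atoms (7 carbon, 2 nitrogen, 1 oxygen; one five-membered aromatic ring with 2 hetero atoms, one six-membered aromatic ring of carbon only) in place of a group of 9 heavy atoms (7 carbon, 2 nitrogen; one five-membered aromatic ring with 1 hetero atom, one six-membered aromatic ring with 1 hetero atom), on an aromatic carbon. The measured steps, an at least 19-fold higher number from compound 1 to compound 3 (1.29 log units; beyond the scatter) and an at least 6.0-fold higher number from compound 2 to compound 3 (0.78 log units; beyond the scatter) among them, all alter the chain end, so none gives a direction for this swap on an aromatic carbon. Compound 4 keeps the chain end of compound 1, which gives 7570 nM, so no step beyond the scatter is expected in this assay. The expected step is a 1.3-fold lower number from compound 1 to compound 4 (0.10 log units; within the scatter). For compound 4 the estimate is 6000 nM, with an expected range of 1200 nM to 25000 nM.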

Compound 4, half-maximal inhibitory concentration: 7220 nM
Compound 4: middle estimate off by 1.2-fold (0.08 log units), on the low side; the range from low to high includes it.
By their numbers in this assay, from the lowest: compounds 4 and 1 (each within the scatter of the next); then compound 2. At a limit, above all of these: compound 3.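

In this assay, 2-amino-1,3-benzoxazol-5-yl on this aromatic carbon gives a 1.0-fold lower number from compound 1 to compound 4 (0.02 log units; within the scatter). Among the compounds shown here, all earlier steps altered the chain end, and this is the first reading at this position: with the chain end of compound 1 kept, the two fused two-ring groups cannot be told apart in this assay. Going by these compounds, what remains open is whether a phenyl ring or an amine on this carbon would read the same, and whether 2-amino-1,3-benzoxazol-5-yl would read the same with the hydroxycarbamoyl chain end of compound 2. No measurement shown here bears on this step.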